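This account rests on a few compounds, and the source may have more. Where it says the series, first, only, none or still open, it means among the compounds named here.

Measured compounds:
- Compound 1, `C#CCSc1nc(N2CCN(C)CC2)c2ccncc2n1`, in a functional assay on PC-3 cells (Homo sapiens) for inhibition, read by MTT assay, with a stated time of 72 h (a lower number here means a stronger inhibitor, a higher number a weaker inhibitor), gives a value that is only a limit of the assay, > 80000 nM.
- Compound 2, `C#CCSc1nc(N2CCN(CC)CC2)c2ccncc2n1`, in this assay likewise gives only a limit, > 80000 nM.
- Compound 3, `CCSc1nc(Nc2cccc(OC)c2)c2ccncc2n1`, in this assay gives 7150 nM.

Compound 4, `CCCSc1nc(Nc2cccc(OC)c2)c2ccncc2n1`, has not yet been measured. It differs from compound 3 by methyl in place of hydrogen on a saturated chain carbon, two bonds along the chain from a sulfur. The same kind of change is seen once already, from compound 1 to compound 2, as methyl in place of hydrogen on a saturated chain carbon bound to an amine nitrogen in a ring. There the place differs: it sits on a saturated chain carbon bound to an amine nitrogen in a ring, whereas in compound 4 it sits on a saturated chain carbon, two bonds along the chain from a sulfur. That earlier step, a step that the two limits leave unreadable from compound 1 to compound 2, cannot be sized because of the limit of > 80000 nM in this assay, at which 2 of the 3 values shown sit. How the core of compound 1 differs from the core of compound 3 is not broken down here.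

Among the compounds with values here, with the one earlier example unreadable, the expectation for compound 4 rests on compound 3 alone at 7150 nM, and a small step, a 1.2-fold lower number from compound 3 to compound 4 (0.08 log units; within the scatter), is expected, within the usual scatter. Compound 4 is therefore estimated at 6000 nM, between 2000 nM and 20000 nM.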

Compound 4, half-maximal inhibitory concentration: 15300 nM
Estimate against measurement, compound 4: 2.6-fold (0.41 log units) below; measured number inside the range.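

In this assay there is a 2.1-fold higher number from compound 3 to compound 4 (0.33 log units; beyond the scatter) as ethylsulfanyl becomes propylsulfanyl, so on the core of compound 3 the added methyl goes with a modestly weaker inhibitor. This is a single step at a single place, and it does not show that the same change would act the same way on another core. The only other example of this kind of change, on the core of compound 1 and at a different place, cannot be read, because compound 1 and compound 2 both give only a limit and no number: the limit of > 80000 nM in this assay, at which 2 of the 4 values shown sit.

The compounds shown leave open whether the number keeps rising with a longer chain such as butylsulfanyl, or whether a sulfur chain carrying an amine or a carboxylic acid would move it in either direction. They also leave open how the step from ethylsulfanyl to propylsulfanyl would read on any other core.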